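The compounds below may be only part of what the source reports. "The series", "measured", "known", "first", "only" and "open" are said of these compounds alone.

Values so far in a functional assay on A549 cells (Homo sapiens) for cytotoxicity, read by MTT assay, with a stated time of 72 h; a lower number here means a stronger inhibitor, a higher number a weaker inhibitor:

Compound 1 `COc1ccc(NC(=O)CN2CCN(c3nnc(Cc4ccncc4)c4ccccc34)CC2)cc1OC` gives 26500 nM
Compound 2 `O=C(CN1CCN(c2nnc(Cc3ccccc3)c3ccccc23)CC1)Nc1ccc(F)c(C(F)(F)F)c1` gives 2480 nM

Of these two numbers, compound 1 holds the higher, and compound 2 lies below it by more than the scatter. The two compounds differ in more than one place, so the gap cannot be tied to any single change. Compound 3 `Cc1ccc(F)cc1NC(=O)CN1CCN(c2nnc(Cc3ccncc3)c3ccccc23)CC1` has not yet been measured. It keeps the rest of compound 1 and changes one group, with 5-fluoro-2-methylphenyl in place of 3,4-dimethoxyphenyl on an amide-type nitrogen. For the measured compounds named here, no measured pair isolates this change. Going by the values given here, the only guide is that compound 2, which also lacks the 3,4-dimethoxyphenyl group, reads 2480 nM in this assay. That is thin support, so only a moderately lower number is expected, and the estimated step is a 2.7-fold lower number from compound 1 to compound 3 (0.42 log units; beyond the scatter). The estimate for compound 3 is 10000 nM, with an expected range from 3000 nM to 30000 nM.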

Compound 3, half-maximal inhibitory concentration: 38900 nM
Compound 3: the middle estimate sits 3.9-fold (0.59 log units) below what was measured, outside the stated range (above it).
By their numbers in this assay, from the lowest: compound 2; then compounds 1 and 3 (each within the scatter of the next).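

In this assay, for the compounds shown here, 5-fluoro-2-methylphenyl in place of 3,4-dimethoxyphenyl on an amide-type nitrogen gives a 1.5-fold higher number from compound 1 to compound 3 (0.17 log units; within the scatter), and this is the first step in the set that isolates a single change. With the rest of compound 1 held fixed, the two groups cannot be told apart at this position, even though the entering group carries a fluorine and a methyl instead of two methoxy groups and counts no hydrogen-bond acceptors, so losing the 3,4-dimethoxyphenyl group does not by itself shift the reading on this scaffold. No supporting data are available that bear on this result.

Compound 2, at 2480 nM, differs from both compound 1 and compound 3 in more than one place, so what sets its value apart stays unresolved. As far as these compounds go, it also remains open whether this amide-type nitrogen would respond to a different kind of substituent, such as a phenyl group carrying a carboxylic acid or an amine, or a longer alkyl chain in place of the aromatic ring.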